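The source may report more compounds than this note shows. Statements on the series, on what has been measured and on what is new or still open speak of the compounds shown alone.

In a functional assay on the whole organism (lung, strain A/J) for inhibition, with Mus musculus as the target, with stated times of 1 h and 18 h, at a dose of 100 umol/kg by the oral route (a higher number here means more inhibition at the dose given (going by the name of the read-out), a lower number less inhibition), compound 2 `COc1ccc(C(=O)N(C)/N=C/c2ccc(OC)c(OC)c2)cc1` gives 81%, the highest of the three measured numbers. Compound 3 `COc1ccc(/C=N/N(C)C(=O)c2ccc(O)cc2)cc1OC` gives 65%, and compound 1 `COc1ccc(/C=N/N(C)C(=O)c2ccc(OC)c(OC)c2)cc1OC` gives 53%. Compound 4 `COc1ccc(/C=N/N(C)C(=O)c2ccc(Cl)cc2)cc1OC` differs from compound 2 by chloro in place of methoxy on an aromatic carbon. For the measured compounds named here, no measured step swaps methoxy for chloro, so the two neighbouring steps serve as guides: a number 28 percentage points higher from compound 1 to compound 2 (beyond the scatter) and a number 16 percentage points lower from compound 2 to compound 3 (beyond the scatter). Both changes to a methoxy group shifted this assay by modest amounts, and the one that altered the methoxy itself lowered it. A modest drop, or no step beyond the scatter, is therefore expected, written as a number 11 percentage points lower from compound 2 to compound 4 (beyond the scatter). Compound 4 is estimated at 70%, with a range from 50% to 90%.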

Compound 4, a percentage reported as inhibition, in the whole organism at one dose (the size of the read-out at that dose, not a potency): 69%
Compound 4: middle estimate off by 1 percentage points, on the high side, and the stated range covers the measured number.
By their numbers in this assay, from the lowest: compound 1; then compounds 3 and 4 (each within the scatter of the next); then compound 2.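

In this assay, this position on the aromatic ring now has a direct comparison of methoxy with chloro, giving a number 12 percentage points lower from compound 2 to compound 4 (beyond the scatter). Replacing that methoxy with chloro therefore costs some inhibition, while chloro and hydroxy cannot be told apart, with a number 4 percentage points higher from compound 3 to compound 4 (within the scatter). No measurement shown explains these differences. From the compounds shown here alone, whether an amine or a carboxylic acid at this position would match the methoxy compound remains open. So does whether a longer chain, such as ethoxy, would keep the inhibition seen with compound 2.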